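Swapping chloro for bromo on two related cores

The source may report more compounds than this note shows. Statements on the series, on what has been measured and on what is new or still open speak of the compounds shown alone.

Compound 1, `CC(=O)N1CCC(Sc2c[nH]c3ccc(Cl)cc23)CC1`, gives 2.9 mg/kg in a functional assay on the whole organism with Mus musculus as the target, in the writhing test; on this read-out lower numbers stand for an effect already at smaller amounts and higher numbers for an effect only at larger amounts of compound.
Compound 2, `CC(=O)N1CCC(Sc2c[nH]c3ccc(Br)cc23)CC1`, gives 2.9 mg/kg in this assay.
Compound 3, `CN1CCC(Sc2cn(C)c3ccc(Cl)cc23)CC1`, gives 3.9 mg/kg in this assay.

Compound 1 and compound 2 differ only by bromo in place of chloro on an aromatic carbon. That change gave no change at the digits printed from compound 1 to compound 2 (within the scatter). Compound 3 has a different core; the difference between the two cores is not broken down here. Compound 4, `CN1CCC(Sc2cn(C)c3ccc(Br)cc23)CC1`, is not yet measured and differs from compound 3 by bromo in place of chloro on an aromatic carbon, the same change as the one already seen, made at the same kind of place. Because no change at the digits printed from compound 1 to compound 2 (within the scatter), the step from compound 3 to compound 4 is expected to be small as well, no change at the digits printed from compound 3 to compound 4 (within the scatter). For compound 4 the estimate in this assay is 3.9 mg/kg, expected to fall between 2.3 mg/kg and 6.5 mg/kg.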

Compound 4, dose for half-maximal effect: 5.4 mg/kg
Beside the measured number, compound 4's estimate is 1.4-fold (0.14 log units) below it, within the range that was stated.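

Bromo in place of chloro on the second core gave a 1.4-fold higher number from compound 3 to compound 4 (0.14 log units; within the scatter) in this assay, so the swap looks alike on both cores: the same change on two cores in this assay, no change at the digits printed (within the scatter) from compound 1 to compound 2 and a 1.4-fold higher number (0.14 log units; within the scatter) from compound 3 to compound 4, 1.4-fold (0.14 log units) apart, within the scatter of two such steps

This shows that, for these two pairs, the swap carried from one core to the other without a step beyond the usual scatter. It does not show that the same would hold on any other core, and steps this small could hide a real difference between the two cores.

On these data alone, whether another group on this aromatic carbon, such as fluoro, a nitrile or a carboxylic acid, would also carry across stays open. As far as these compounds go, the separate effect of each difference between the two cores also stays open.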